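Phenethyl Amide to Tolyl Urea on the Shared Core

A few compounds are considered here, and "the series" means these few. Any claim that something is new, unique, unknown or untested is made for them only; others in the source may bear on it.

Three compounds share one core and differ only in the group on an amine nitrogen in a ring. Compound 1 `COc1ccc(-c2cnc3nc(N)nc(N4CCN(Cc5ccccc5F)CC4)c3n2)cc1OC` carries a 2-fluorobenzyl there, and in a functional assay on cells (T-cell, Homo sapiens) for inhibition (on this read-out lower numbers stand for stronger inhibition and higher numbers for weaker inhibition), compound 1 gives 700 nM. Compound 2 `COc1ccc(-c2cnc3nc(N)nc(N4CCN(C(=O)Nc5ccccc5)CC4)c3n2)cc1OC` carries a phenylcarbamoyl, and compound 2 gives 3.4 nM, the step being a 210-fold lower number from compound 1 to compound 2 (2.31 log units; beyond the scatter). Compound 3 `COc1ccc(-c2cnc3nc(N)nc(N4CCN(C(=O)CCc5ccccc5)CC4)c3n2)cc1OC` carries a phenethylcarbonyl, and compound 3 gives 100 nM; it stands second highest of the three numbers, the nearer step being a 7.0-fold lower number from compound 1 to compound 3 (0.85 log units; beyond the scatter) and the further step being a 29-fold higher number from compound 2 to compound 3 (1.47 log units; beyond the scatter).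

Compound 4 `COc1ccc(-c2cnc3nc(N)nc(N4CCN(C(=O)Nc5ccc(C)cc5)CC4)c3n2)cc1OC` differs from compound 3 by (4-methylphenyl)amino in place of phenethyl on a carbonyl carbon. Among the compounds with values here, the measured step that bears on this is the one from compound 2 to compound 3, a 29-fold higher number from compound 2 to compound 3 (1.47 log units; beyond the scatter), which ran in the opposite direction with a large size. Within the data shown here, no measured pair shows what the added methyl on the ring does. Compound 4 is therefore expected to give 5 nM, with a range from 1.5 nM to 20 nM. That estimate amounts to an expected step of a 20-fold lower number from compound 3 to compound 4 (1.30 log units; beyond the scatter).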

Compound 4, half-maximal inhibitory concentration: 0.8 nM
For compound 4 the middle estimate is 6.3-fold (0.80 log units) above the measured one, and the stated range ends above it.
By their numbers in this assay, from the lowest: compound 4; then compound 2; then compound 3; then compound 1.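

The methyl added to the ring has a measurable effect in this assay: the step of a 4.3-fold lower number from compound 2 to compound 4 (0.63 log units; beyond the scatter) is modest but beyond the scatter, so this part of the group accepts a methyl without loss. The (4-methylphenyl)amino group in place of phenethyl on a carbonyl carbon gives a 130-fold lower number from compound 3 to compound 4 (2.10 log units; beyond the scatter) and so goes further than the reverse of the earlier step of a 29-fold higher number from compound 2 to compound 3 (1.47 log units; beyond the scatter) on the unsubstituted ring. Replacing 2-fluorobenzyl with (4-methylphenyl)carbamoyl gives an 880-fold lower number from compound 1 to compound 4 (2.94 log units; beyond the scatter) and leaves compound 4 with the lowest number of the four, beyond the scatter of each other compound.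

On these data alone, whether a chlorine atom or a methoxy group on that ring would match the methyl remains open. Nothing available explains any of these steps.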